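This account rests on a few compounds, and the source may have more. Where it says the series, first, only, none or still open, it means among the compounds named here.

Three compounds share one core. Compound 1 `CN1CCN(c2ccc(Nc3nc(-c4cccc(NC(=O)c5ccccc5)c4)sc3C(=O)O)cc2)CC1` and compound 2 `CN1CCN(c2ccc(Nc3nc(-c4cccc(NC(=O)c5ccccc5)c4)sc3C(N)=O)cc2)CC1` are close relatives, but in a functional assay on Raji cells (Homo sapiens) for antiproliferative activity, read by CCK-8 assay, with a stated time of 72 h (a lower number here means a stronger inhibitor, a higher number a weaker inhibitor), compound 1 stands as "not determined" (no result reported), so it carries no number. In this assay, within the data shown here, compound 2 gives 6360 nM, which places it as the only compound with a measured value here; with compound 1 lacking one, no measured step between compounds can be drawn, and nothing can be said about how any change has moved the number so far. Compound 3 `CN1CCN(c2ccc(Nc3nc(-c4cccc(NC(=O)c5ccco5)c4)sc3C(N)=O)cc2)CC1` is the compound still to be measured. It differs from compound 2 in one place: furan-2-yl in place of phenyl on a carbonyl carbon. Among the measured compounds shown here, no measured pair here shows what such a swap does, so the expectation rests on the single number for compound 2 and on the modest size of the change. A step of this kind is expected to fall within the usual scatter, in no clear direction. Compound 3 is expected to give about 5500 nM, within a range from 1800 nM to 17000 nM. The step that this estimate means is expected to be a 1.2-fold lower number from compound 2 to compound 3 (0.06 log units; within the scatter).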

Compound 3, half-maximal inhibitory concentration: 37400 nM
For compound 3 the middle estimate is 6.8-fold (0.83 log units) below the measured one; measured number outside the range, above it.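

In this assay, among these compounds, placing furan-2-yl instead of phenyl on the carbonyl carbon gives a 5.9-fold higher number from compound 2 to compound 3 (0.77 log units; beyond the scatter), the first measured step, and it shows that this position is sensitive to which ring it carries. The change looks small on paper, since a six-membered aromatic ring of carbon only gives way to a five-membered aromatic ring with 1 hetero atom, which adds 1 hydrogen-bond acceptor and no net charge, yet the step lies beyond the usual scatter and leaves compound 3 the weaker inhibitor of the two. Nothing measured here explains why this ring swap raises the number.

Among the compounds shown here, compound 1 carries no number, so no step involving it can be read, and the effect of its carboxylic acid on cell growth stays unknown. Going by these compounds, with only phenyl and furan-2-yl compared, it also remains open whether a ring such as thiophen-2-yl or cyclohexyl on the same carbonyl carbon would stay close to compound 2 or fall off as compound 3 does.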